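The source may report more compounds than this note shows. Statements on the series, on what has been measured and on what is new or still open speak of the compounds shown alone.

Measured in a functional assay on RAW264.7 cells (Mus musculus) for inhibition, read by ELISA, with a stated time of 24 h; a higher number here means that more compound is needed for the effect, a lower number that less compound is needed:
- compound 1 `CC/C=C\C[C@H]1C(=O)C=C[C@H]1CC(=O)Oc1ccc(O)cc1`: 23000 nM
- compound 2 `CC/C=C\C[C@H]1C(=O)C=C[C@H]1CC(=O)OCCOCCO`: 36000 nM

Of these two measured compounds, compound 2, at 36000 nM, sits within the scatter of compound 1, so neither can be ranked above the other. The next compound, compound 3 `CC/C=C\C[C@H]1C(=O)C=C[C@H]1CC(=O)OC(C)COC`, keeps the shared core and changes only the ester group: 1-(methoxymethyl)ethyl in place of 2-(2-hydroxyethoxy)ethyl on an oxygen next to a carbonyl group. Going by the values given here, one measured step bears on this, made on an oxygen next to a carbonyl group: a 1.6-fold higher number from compound 1 to compound 2 (0.19 log units; within the scatter). That exchange of 4-hydroxyphenyl for 2-(2-hydroxyethoxy)ethyl stayed within the scatter. Among the compounds with values here, no measured compound carries 1-(methoxymethyl)ethyl, so the evidence is thin. Nothing beyond the scatter is therefore expected in this assay, in either direction. The expected step is small: a 1.2-fold lower number from compound 2 to compound 3 (0.08 log units; within the scatter). For compound 3 the estimated value is 30000 nM, with an expected range from 12000 nM to 70000 nM.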

Compound 3, half-maximal effective concentration: 23000 nM
For compound 3 the middle estimate is 1.3-fold (0.12 log units) above the measured one; the measured number falls inside the stated range.
By their numbers in this assay, from the lowest: compounds 1, 3 and 2 (each within the scatter of the next).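

In this assay the exchange of 2-(2-hydroxyethoxy)ethyl for 1-(methoxymethyl)ethyl on this oxygen gives a 1.6-fold lower number from compound 2 to compound 3 (0.19 log units; within the scatter), so removing the hydrogen-bond donor of the outgoing group leaves the number within the scatter. Putting 1-(methoxymethyl)ethyl in place of 4-hydroxyphenyl gives no change at the digits printed from compound 1 to compound 3 (within the scatter), which means that none of the three ester groups shown can be ranked above another in this assay. No measurement on hand accounts for this result.

The compounds shown leave open whether any group on this oxygen can move the number beyond the scatter, for example an amine, a carboxylic acid or a longer chain. They also leave open what a change elsewhere on the shared core would do.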